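Replacing 2,4-dimethylphenyl with 4-methoxyphenyl on the carbonyl

A few compounds are considered here, and "the series" means these few. Any claim that something is new, unique, unknown or untested is made for them only; others in the source may bear on it.

In a functional assay on HepG2 cells (Homo sapiens) for antiproliferative activity, read by MTT assay, with a stated time of 48 h (on this read-out lower numbers stand for stronger inhibition and higher numbers for weaker inhibition), compound 1 `COc1ccc(/C=C/c2cc(OC)cc(OC)c2/C=C/C(=O)c2cccc(OC)c2)cc1` gives 11.6 ug/mL and compound 2 `COc1ccc(/C=C/c2cc(OC)cc(OC)c2/C=C/C(=O)c2cccc(Cl)c2)cc1` gives 9.5 ug/mL. That gap, a 1.2-fold lower number from compound 1 to compound 2 (0.09 log units; within the scatter), is small. Compound 3 `COc1ccc(/C=C/c2cc(OC)cc(OC)c2/C=C/C(=O)c2ccc(C)cc2C)cc1` has the lowest number of the three, 0.9 ug/mL. Unmeasured compound 4 `COc1ccc(/C=C/c2cc(OC)cc(OC)c2/C=C/C(=O)c2ccc(OC)cc2)cc1` has 4-methoxyphenyl in place of 2,4-dimethylphenyl on a carbonyl carbon. The closest guides are the two large steps into the 2,4-dimethylphenyl group, a 13-fold lower number from compound 1 to compound 3 (1.11 log units; beyond the scatter) and an 11-fold lower number from compound 2 to compound 3 (1.02 log units; beyond the scatter). Read backwards, they suggest that leaving this group raises the number, though three compounds are a thin basis. The expected change is a 6.7-fold higher number from compound 3 to compound 4 (0.82 log units; beyond the scatter). For compound 4 the estimated value is 6 ug/mL, with an expected range of 1.5 ug/mL to 15 ug/mL.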

Compound 4, half-maximal inhibitory concentration: 4.9 ug/mL
The estimate for compound 4 lay 1.2-fold (0.09 log units) above the measured number; the range from low to high includes it.
By their numbers in this assay, from the lowest: compound 3; then compounds 4, 2 and 1 (each within the scatter of the next, the first and the last beyond it).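

In this assay, the group on the carbonyl matters even among methoxy-bearing rings: 4-methoxyphenyl in place of 3-methoxyphenyl gives a 2.4-fold lower number from compound 1 to compound 4 (0.37 log units; beyond the scatter). Against 3-chlorophenyl, the same group gives a 1.9-fold lower number from compound 2 to compound 4 (0.29 log units; within the scatter), while leaving 2,4-dimethylphenyl still gives a 5.4-fold higher number from compound 3 to compound 4 (0.74 log units; beyond the scatter), so compound 3 remains the most active of the four. No measurement shown here explains these differences. Open, on these data alone, is how a 4-methylphenyl or a 2-methylphenyl group would read alone, which would separate the two methyl groups of compound 3, and how an amine on this ring would read.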